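The compounds below may be only part of what the source reports. "The series", "measured", "known", "first", "only" and "open" are said of these compounds alone.

This piece concerns four close relatives that share one core and a three-membered non-aromatic ring with one nitrogen, all judged in an ADME assay on MRC5 cells (Homo sapiens) for cytotoxicity, read by MTT assay, with a stated time of 48 h; a lower number here means a stronger inhibitor, a higher number a weaker inhibitor. Compound 1 `CCCCCCCCCCCCCCC1(CO[C@@H]2O[C@@H]3CO[C@H](c4ccccc4)O[C@@H]3[C@H](OCc3ccccc3)[C@H]2OCc2ccccc2)CN1S(=O)(=O)c1ccc(C)cc1` is the only one of the three measured that gives a plain number: in this assay compound 1 gives 1000000 nM. Compound 2 `Cc1ccc(S(=O)(=O)N2C(C)C2CO[C@@H]2O[C@@H]3CO[C@H](c4ccccc4)O[C@@H]3[C@H](OCc3ccccc3)[C@H]2OCc2ccccc2)cc1` does not reach a number. In this assay compound 2 gives > 1000000 nM, which is a limit of the assay and not a number. Compound 3 `Cc1ccc(S(=O)(=O)N2CC2(C)CO[C@@H]2O[C@@H]3CO[C@H](c4ccccc4)O[C@@H]3[C@H](OCc3ccccc3)[C@H]2OCc2ccccc2)cc1` ends the same way. In this assay compound 3 gives > 1000000 nM, again a limit and not a number. Compound 3 therefore stands where two of the three results stand, at the limit of > 1000000 nM in this assay, at which 2 of the 3 values shown sit, and the three values shown do not separate it from compound 1 or compound 2.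

Compound 4 `Cc1ccc(S(=O)(=O)N2CC2CO[C@@H]2O[C@@H]3CO[C@H](c4ccccc4)O[C@@H]3[C@H](OCc3ccccc3)[C@H]2OCc2ccccc2)cc1` differs from compound 3 in one place: hydrogen in place of methyl on a saturated ring carbon. Among the compounds with values here, no measured pair shows what this change does here, and the three values shown lie together. I therefore expect no step beyond the scatter in this assay, in either direction, which is an estimated step of a number no higher from compound 3 to compound 4 (the limit leaves the size open). Compound 4 is estimated to give 1000000 nM in this assay, in a range from 500000 nM to 2000000 nM, most likely reported once more only as a limit.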

Compound 4, half-maximal inhibitory concentration: 183000 nM
For compound 4 the middle estimate is 5.5-fold (0.74 log units) above the measured one; measured number below the stated range.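

The earlier compounds shown here offered no pair that isolated this change, and these first pairs show that it matters: in this assay, hydrogen in place of methyl on a saturated ring carbon gives an at least 5.4-fold lower number from compound 3 to compound 4 (0.73 log units; beyond the scatter), and the same exchange gives an at least 5.4-fold lower number from compound 2 to compound 4 (0.73 log units; beyond the scatter). Among these three compounds, only compound 4, which carries no methyl on the three-membered ring, gives a number instead of a limit, so a single methyl on a carbon of this ring is enough to separate the results. On these data alone, the true size of both steps stays open, since each starts from a limit and not from a number: the limit of > 1000000 nM in this assay, at which 2 of the 4 values shown sit.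

The compounds shown leave open how other small groups would behave at this ring carbon, for example an ethyl, a hydroxymethyl or an amine, and so whether the result is specific to methyl or extends to any group placed there. They also give no measured property of these compounds that could explain why removing the methyl lowers the number, so the reason for the step remains unknown.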